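Replacing the Oxazole in Compound 2 with a Methylthiophene

The compounds below may be only part of what the source reports. "The series", "measured", "known", "first", "only" and "open" are said of these compounds alone.

Measured so far:
compound 1 `Cc1nc(-c2ccccc2NCC2=NCCN2)cs1`, 4.47 nM
compound 2 `Cc1nc(-c2ccccc2NCC2=NCCN2)co1`, 324 nM

For the measured compounds named here, in a functional assay for activation of Alpha-1A adrenergic receptor (Homo sapiens), read by calcium flux (on this read-out higher numbers stand for an effect only at larger amounts of compound and lower numbers for an effect already at smaller amounts), compound 2 gives 324 nM, the highest of the two numbers known; its nearest neighbour is compound 1, and the step of a 72-fold higher number from compound 1 to compound 2 (1.86 log units; beyond the scatter) separates them. That step is the only one measured, and it consists of putting the oxygen-containing five-membered ring of compound 2 in place of the sulfur-containing one of compound 1.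

Compound 3 `Cc1ccsc1-c1ccccc1NCC1=NCCN1` is the unmeasured member of the set. It differs from compound 2 by 3-methylthiophen-2-yl in place of 2-methyl-1,3-oxazol-4-yl on an aromatic carbon. The entering ring again carries a sulfur atom, as the ring of compound 1 did, while the nitrogen and oxygen of the ring in compound 2 are gone. Going by the values given here, since the only measured step, a 72-fold higher number from compound 1 to compound 2 (1.86 log units; beyond the scatter), was large and went upward when the sulfur-containing ring left, the account expects the reverse direction when a sulfur-containing ring returns: a large step downward in this assay, though the second ring is not identical to that of compound 1, so the full size of that step is uncertain. The expected step is a 27-fold lower number from compound 2 to compound 3 (1.43 log units; beyond the scatter). Compound 3 is therefore estimated at 12 nM, with a range from 2.5 nM to 60 nM.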

Compound 3, half-maximal effective concentration: 0.851 nM
Beside the measured number, compound 3's estimate is 14-fold (1.15 log units) above it; measured number outside the range, below it.
By their numbers in this assay, from the lowest: compound 3; then compound 1; then compound 2.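

In this assay, the position on an aromatic carbon of the six-membered aromatic ring tolerates more than a return to the ring of compound 1: 3-methylthiophen-2-yl gives a 380-fold lower number from compound 2 to compound 3 (2.58 log units; beyond the scatter) and, beyond that, a 5.3-fold lower number from compound 1 to compound 3 (0.72 log units; beyond the scatter), so compound 3 has the lowest number of the three. For the compounds shown here, the sulfur-bearing rings of compound 1 and compound 3 both stand below the oxazole of compound 2, with no compound of the three against this, and the ring nitrogen shared by compound 1 and compound 2 is evidently not needed for a low number, since the ring of compound 3 has neither nitrogen nor oxygen. No evidence is at hand to explain these differences.

The change from compound 2 to compound 3 alters the hetero atoms and the place of the methyl together, so the compounds shown cannot separate what each contributes. Also open, going by these compounds, is how a thiophene without the methyl, a furan or a plain phenyl ring would read at this position, and whether the order of the three compounds holds at any other receptor.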